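From (4-methylphenyl)amino to (4-ethoxyphenyl)amino

A few compounds are considered here, and "the series" means these few. Any claim that something is new, unique, unknown or untested is made for them only; others in the source may bear on it.

In a functional assay on SAOS-2 cells (Homo sapiens) for antiproliferative activity, read by MTT assay, with a stated time of 72 h (on this read-out higher numbers stand for weaker inhibition and lower numbers for stronger inhibition), compound 1 `CCOC1=C(C(=O)c2ccccc2)C(c2ccc(Br)cc2)N(CCCn2ccnc2)C1=O` gives 31700 nM, compound 2 `NC1=C(C(=O)c2ccccc2)C(c2ccc(Br)cc2)N(CCCn2ccnc2)C1=O` gives 107000 nM, and compound 3 `Cc1ccc(NC2=C(C(=O)c3ccccc3)C(c3ccc(Br)cc3)N(CCCn3ccnc3)C2=O)cc1` gives 31900 nM, the second highest of the three, matched by compound 1 (a 1.0-fold higher number from compound 1 to compound 3 (0.00 log units; within the scatter)) and set apart from compound 2 (a 3.4-fold lower number from compound 2 to compound 3 (0.53 log units; beyond the scatter)). Compound 4 `CCOc1ccc(NC2=C(C(=O)c3ccccc3)C(c3ccc(Br)cc3)N(CCCn3ccnc3)C2=O)cc1` differs from compound 3 by ethoxy in place of methyl on an aromatic carbon. Going by the values given here, no measured step touches that aromatic carbon: the measured changes, a 3.4-fold higher number from compound 1 to compound 2 (0.53 log units; beyond the scatter) and a 1.0-fold higher number from compound 1 to compound 3 (0.00 log units; within the scatter), all sit on the double-bonded ring carbon, so they do not bear directly on this change. In this assay compound 4 is therefore expected to move by a 1.1-fold lower number from compound 3 to compound 4 (0.03 log units; within the scatter), nothing beyond the scatter, with an estimate of 30000 nM, between 10000 nM and 90000 nM.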

Compound 4, half-maximal inhibitory concentration: 30900 nM
Compound 4: the middle estimate sits 1.0-fold (0.01 log units) below what was measured; measured number inside the range.
By their numbers in this assay, from the lowest: compounds 4, 1 and 3 (each within the scatter of the next); then compound 2.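

In this assay, ethoxy in place of methyl on this aromatic carbon, para to a large group, leaves the number within the scatter (a 1.0-fold lower number from compound 3 to compound 4 (0.01 log units; within the scatter)), so the two groups cannot be told apart here. The step from the free amine holds with the new group (a 3.5-fold lower number from compound 2 to compound 4 (0.54 log units; beyond the scatter)), while (4-ethoxyphenyl)amino stays level with plain ethoxy on the double-bonded ring carbon (a 1.0-fold lower number from compound 1 to compound 4 (0.01 log units; within the scatter)). Nothing measured explains this insensitivity. The compounds shown leave open whether a carboxylic acid, an amine or a longer alkoxy chain on this aromatic carbon would move the number.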